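Changing the Aromatic Group on the Core of Compound 1

This account rests on a few compounds, and the source may have more. Where it says the series, first, only, none or still open, it means among the compounds named here.

In an ADME assay (Rattus norvegicus, strain Wistar Han) for metabolic stability (on this read-out lower numbers stand for a shorter-lived compound and higher numbers for a longer-lived compound), compound 1 `CCn1c(-c2cnc(C)nc2)nc2c(O[C@H]3CCN(C(=O)C4CC4)C3)ncnc21` gives 1.8 h. Among the three compounds measured so far it stands second highest. Compound 2 `CCC(=O)N1CC[C@H](Oc2ncnc3c2nc(-c2cnc(C)nc2)n3CC)C1` gives 1.2 h; the step of a 1.5-fold lower number from compound 1 to compound 2 (0.18 log units; within the scatter) lies within the scatter, so the two values cannot be told apart. Within the data shown here, compound 3 `CCn1c(-c2cnc(C)nc2)nc2c(N[C@H]3CCN(C(=O)N4CC(OC)C4)C3)ncnc21` gives 4 h, the highest of the three and beyond the scatter from compound 1; compound 3 differs from compound 1 in more than one place, so no single step joins them.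

Compound 4 `CCn1c(-c2ccc(C(F)(F)F)nc2)nc2c(O[C@H]3CCN(C(=O)C4CC4)C3)ncnc21` has not yet been measured in this assay. It differs from compound 1 in one place: 6-(trifluoromethyl)pyridin-3-yl in place of 2-methylpyrimidin-5-yl on an aromatic carbon. Among the measured compounds shown here, none of the measured steps concerns this position. For the measured compounds named here, the only step with a single change, from compound 1 to compound 2, altered the group on the carbonyl carbon and stayed within the scatter. The data therefore give no direct guide to the size or direction of this change. The step is expected to be a 1.2-fold higher number from compound 1 to compound 4 (0.09 log units; within the scatter), a change within the scatter. Compound 4 is estimated at 2.2 h, between 0.9 h and 5.5 h. Going by the values given here, the range is wide; no measured step bears on this change.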

Compound 4, half-life: 0.7 h
The estimate for compound 4 lay 3.1-fold (0.50 log units) above the measured number; measured number below the stated range.
By their numbers in this assay, from the lowest: compounds 4, 2 and 1 (each within the scatter of the next, the first and the last beyond it); then compound 3.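

In this assay, putting 6-(trifluoromethyl)pyridin-3-yl in place of 2-methylpyrimidin-5-yl on the aromatic carbon between two ring nitrogen atoms gives a 2.6-fold lower number from compound 1 to compound 4 (0.41 log units; beyond the scatter) and so shows that this position can move the half-life by more than the scatter, toward a shorter-lived compound. The earlier single change, on the carbonyl carbon, gave a 1.5-fold lower number from compound 1 to compound 2 (0.18 log units; within the scatter) and revealed nothing about this aromatic group. The swap alters two things at once, as the ring goes from 2 hetero atoms to 1 hetero atom and methyl gives way to trifluoromethyl, and nothing shown says what lies behind the drop.

The compounds shown leave open whether the ring or its substituent accounts for the step, which 6-methylpyridin-3-yl or 2-(trifluoromethyl)pyrimidin-5-yl on the same carbon could separate. Also open, on these data alone, is whether the same swap would give a similar step on compound 2, which carries an ethyl group on the carbonyl carbon in place of cyclopropyl.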